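A few compounds are considered here, and "the series" means these few. Any claim that something is new, unique, unknown or untested is made for them only; others in the source may bear on it.

Measured so far:
compound 1, `CN(C)CCC(OC(=O)c1ccc(C(F)(F)F)cc1)c1ccc(Cl)cc1`: 47%
compound 2, `CN(C)CCC(OC(=O)c1ccc(-c2ccccc2)cc1)c1ccc(Cl)cc1`: 53%
compound 3, `CN(C)CCC(NC(=O)Nc1ccc(C(F)(F)F)cc1)c1ccc(Cl)cc1`: 105%

In an assay on NIH3T3 cells with Urotensin-2 receptor (Homo sapiens) as the target (a higher number here means a larger maximal response, a lower number a smaller maximal response), compound 1 gives 47% and compound 2 gives 53%. These two share one core and differ in a single place: phenyl in place of trifluoromethyl on an aromatic carbon. That change made a step of a number 6 percentage points higher from compound 1 to compound 2 (within the scatter). Compound 3 gives 105% in this assay and stands highest of the three; its core is not the same as the core of compound 1, and the difference between the two cores is not broken down here. Compound 4, `CN(C)CCC(NC(=O)Nc1ccc(-c2ccccc2)cc1)c1ccc(Cl)cc1`, has not yet been measured. It differs from compound 3 exactly as compound 2 differs from compound 1: phenyl in place of trifluoromethyl on an aromatic carbon. Because the same change at the same place made a step of a number 6 percentage points higher from compound 1 to compound 2 (within the scatter), the step from compound 3 to compound 4 is expected to be of a similar small size, no change at the digits printed from compound 3 to compound 4 (within the scatter). This rests on a single measured pair, so the expectation is loose. Compound 4 is therefore estimated at 105%, with a likely range from 85% to 122%.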

Compound 4, largest response reached (reported as efficacy), in percent of the reference or control that the assay uses: 91%
Compound 4: middle estimate off by 14 percentage points, on the high side; the measured number falls inside the stated range.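

In this assay, putting phenyl in place of trifluoromethyl on an aromatic carbon made a step of a number 14 percentage points lower from compound 3 to compound 4 (beyond the scatter), so the change behaved differently on the core of compound 3 than on the core of compound 1. Set side by side, the two results show that the size and direction of the step did not carry over from one core to the other: the same change on two cores in this assay, a number 6 percentage points higher (within the scatter) from compound 1 to compound 2 and a number 14 percentage points lower (beyond the scatter) from compound 3 to compound 4, 20 percentage points apart, beyond the scatter of two such steps This shows that a step measured on one of these cores was not a safe guide to the step on the other, but with only two pairs it does not show which part of the cores is responsible, nor what the same change would do on a third core.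

The compounds shown carry only trifluoromethyl or phenyl at this place, so it remains open how a methoxy group, a nitrile or a carboxylic acid would fare there on either core. Also open is whether the gap between the two steps would hold for other pairs of groups.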